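The source may report more compounds than this note shows. Statements on the series, on what has been measured and on what is new or still open speak of the compounds shown alone.

Measured compounds:
- compound 1, `CC(C)(C)OC(=O)NCCCNC(=O)CN1CN(c2ccccc2)C2(CCN(C(=O)c3ccc(C4CCCCC4)cc3)CC2)C1=O`, 6000 nM
- compound 2, `O=C(CN1CN(c2ccccc2)C2(CCN(C(=O)c3ccc(C4CCCCC4)cc3)CC2)C1=O)N1CCC(CO)CC1`, 1100 nM
- compound 3, `O=C(CN1CN(c2ccccc2)C2(CCN(C(=O)c3ccc(C4CCCCC4)cc3)CC2)C1=O)NCCCCO`, 10300 nM

All three share one core and differ only in the group carried by the side-chain carbonyl. In an assay on HEK293 cells for displacement of a labelled ligand from NPC1-like intracellular cholesterol transporter 1 (Homo sapiens) (a lower number here means a stronger inhibitor, a higher number a weaker inhibitor), compound 3 gives the highest number of the three; compound 1 sits close, since a 1.7-fold higher number from compound 1 to compound 3 (0.23 log units; within the scatter), while compound 2 lies clearly lower, as a 9.4-fold higher number from compound 2 to compound 3 (0.97 log units; beyond the scatter) shows.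

Compound 4, `COC(=O)CCNC(=O)CN1CN(c2ccccc2)C2(CCN(C(=O)c3ccc(C4CCCCC4)cc3)CC2)C1=O`, is not yet measured. It changes compound 3 by methoxycarbonyl in place of 2-hydroxyethyl on a saturated chain carbon, two bonds along the chain from an amide-type nitrogen, so the open chain is kept but shortened and its hydroxyl end becomes an ester.

The step that bears most on this is a 1.7-fold higher number from compound 1 to compound 3 (0.23 log units; within the scatter): exchanging one chain end for another left this assay essentially unchanged. The larger movement, a 5.5-fold lower number from compound 1 to compound 2 (0.74 log units; beyond the scatter), came only when the open chain was replaced by a ring-closed amide, which compound 4 does not do. A step near the scatter is therefore expected, with perhaps a slight lowering toward compound 1, so compound 4 is estimated at 7000 nM (range 3000 nM to 20000 nM), which is expected to mean a 1.5-fold lower number from compound 3 to compound 4 (0.17 log units; within the scatter).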

Compound 4, half-maximal inhibitory concentration: 12900 nM
Beside the measured number, compound 4's estimate is 1.8-fold (0.27 log units) below it; low and high end bracket the measured number.
By their numbers in this assay, from the lowest: compound 2; then compounds 1, 3 and 4 (each within the scatter of the next, the first and the last beyond it).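

In this assay, methoxycarbonyl in place of 2-hydroxyethyl leaves the result within the scatter, with a 1.3-fold higher number from compound 3 to compound 4 (0.10 log units; within the scatter), even though the entering group has 0 hydrogen-bond donors where the leaving group has 1. The 4-(hydroxymethyl)piperidin-1-yl group on the carbonyl carbon now stands clearly apart from a second open chain, with a 12-fold higher number from compound 2 to compound 4 (1.07 log units; beyond the scatter), so the gap seen with the hydroxyl chain also holds for an ester chain. The two open chains with the most different ends separate only modestly, with a 2.2-fold higher number from compound 1 to compound 4 (0.33 log units; beyond the scatter), a gap just beyond the scatter.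

Nothing here explains why the ring-closed amide differs from the open chains. Going by these compounds, whether an open chain ending in a carboxylic acid or an amine would stay with these chains or move toward the ring-closed amide remains open.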